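Methyl to Trifluoromethyl on a Shared Core

The source may report more compounds than this note shows. Statements on the series, on what has been measured and on what is new or still open speak of the compounds shown alone.

Within the data shown here, compound 1 `CSc1ccc(C)cc1NCC1=NCCN1` is the only compound here with a true number. In an assay on CHO cells for binding affinity to Alpha-2B adrenergic receptor (Homo sapiens), read by radioligand binding (a higher number here means a weaker inhibitor, a lower number a stronger inhibitor), compound 1 gives 977 nM. Compound 2 `Cc1ccc(S(C)(=O)=O)c(NCC2=NCCN2)c1` carries a methylsulfonyl in place of the methylsulfanyl of compound 1. In this assay compound 2 gives < 6310 nM, which is a limit of the assay and not a number. Compound 3 `CS(=O)(=O)c1c(F)cccc1NCC1=NCCN1` also gives only a limit in this assay, < 6310 nM. Among the measured compounds shown here, the step that the limit leaves unreadable from compound 1 to compound 2 therefore cannot be sized because of the limit of < 6310 nM in this assay, at which 2 of the 3 values shown sit, and no measured step with a readable size exists at all.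

Compound 4 `CSc1ccc(C(F)(F)F)cc1NCC1=NCCN1` differs from compound 1 by trifluoromethyl in place of methyl on an aromatic carbon. For the measured compounds named here, none of the measured compounds changes this position, so no measured step bears directly on it, and the one step that touches the core, from compound 1 to compound 2, is itself unreadable. With nothing to point either way, the expectation is a step of a 1.0-fold higher number from compound 1 to compound 4 (0.01 log units; within the scatter) that stays within the usual scatter of this assay, in no particular direction. Compound 4 is therefore estimated at 1000 nM in this assay, with a range from 300 nM to 4000 nM reflecting the thin evidence.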

Compound 4, inhibition constant: 1660 nM
Compound 4: the middle estimate sits 1.7-fold (0.22 log units) below what was measured, within the range that was stated.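

In this assay, trifluoromethyl in place of methyl, on the aromatic carbon para to the methylsulfanyl group, gives a 1.7-fold higher number from compound 1 to compound 4 (0.23 log units; within the scatter). This is the first step among the compounds shown that can be read, and the first to test this position: compound 1 and compound 4 cannot be told apart, so in this one pair the swap from methyl to trifluoromethyl, with its three fluorine atoms, leaves binding affinity within the usual scatter of repeated measurements. The other step, from methylsulfanyl to methylsulfonyl, still cannot be read, and no comparison can be drawn from it because of the assay limit: the limit of < 6310 nM in this assay, at which 2 of the 4 values shown sit.

As far as these compounds go, only methyl and trifluoromethyl can be compared at this position, so what a chlorine atom, a methoxy group, an amine, a carboxylic acid or a longer chain would give there remains open. Also open, from the compounds shown here alone, is whether the same swap would give a similar result on a core carrying methylsulfonyl in place of methylsulfanyl.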